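Methoxy to methyl on compound 2

This account rests on a few compounds, and the source may have more. Where it says the series, first, only, none or still open, it means among the compounds named here.

Compound 1 `COc1ccc2cc([C@H](C)c3nnc(SCc4c(C)cc(C)cc4C)n3-c3cccc(Cl)c3)ccc2c1` gives 93300 nM
Compound 2 `COc1ccc(CSc2nnc([C@@H](C)c3ccc4cc(OC)ccc4c3)n2-c2ccc(Cl)cc2)cc1` gives 72600 nM
Compound 3 `COc1ccc2cc([C@H](C)c3nnc(SCc4c(Cl)cccc4Cl)n3-c3cccc(Cl)c3)ccc2c1` gives <= 400000 nM as a limit

All three values come from a functional assay on DU-145 cells (Homo sapiens) for cytotoxicity, read by MTT assay (on this read-out higher numbers stand for weaker inhibition and lower numbers for stronger inhibition), and nothing else. Compound 2 at 72600 nM and compound 1 at 93300 nM lie within the scatter of each other. The entry for compound 3 is a limit and not a number. Among the compounds with values here, the only measured single change is a step that the limit leaves unreadable from compound 1 to compound 3 and it offers no size to carry over. Compound 4 `COc1ccc2cc([C@H](C)c3nnc(SCc4ccc(C)cc4)n3-c3ccc(Cl)cc3)ccc2c1` keeps the rest of compound 2 and turns 4-methoxybenzyl into 4-methylbenzyl (methyl in place of methoxy on an aromatic carbon) with methyl in place of methoxy on an aromatic carbon. Within the data shown here, with no measured step to guide it, the expected 1.1-fold higher number from compound 2 to compound 4 (0.04 log units; within the scatter) stays within the scatter and has no clear direction. Compound 4 is expected at 80000 nM within a range from 35000 nM to 200000 nM by this estimate.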

Compound 4, half-maximal inhibitory concentration: 18800 nM
Compound 4: the middle estimate sits 4.3-fold (0.63 log units) above what was measured, and the stated range ends above it.
By their numbers in this assay, from the lowest: compound 4; then compounds 2 and 1 (each within the scatter of the next).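

In this assay, within the data shown here, methyl in place of methoxy gives a 3.9-fold lower number from compound 2 to compound 4 (0.59 log units; beyond the scatter), the first single change in this set with a readable size. It shows that a small swap on this aromatic carbon, para to a large group, can move the number beyond the scatter. Nothing measured here bears on why the number falls.

As far as these compounds go, whether an amine or a carboxylic acid on the same carbon would give a lower or higher number remains open. So does whether an ethyl group would carry the trend further.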